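Changing the chain on the aromatic nitrogen

The compounds below may be only part of what the source reports. "The series", "measured", "known", "first", "only" and "open" are said of these compounds alone.

Compound 1 `CN1CCN(CCCCCCn2c3c(c4ccccc42)C(=O)c2c[n+]([O-])c4ccccc4c2C3=O)CC1`: in a functional assay on SH-SY5Y cells (Homo sapiens) for cytotoxicity, read by MTT assay, with a stated time of 72 h (on this read-out lower numbers stand for stronger inhibition and higher numbers for weaker inhibition), compound 1 gives 920 nM.
Compound 2 `O=C1c2c[n+]([O-])c3ccccc3c2C(=O)c2c1c1ccccc1n2Cc1cn(C[C@H](O)CO)nn1`: in this assay compound 2 gives only > 1000 nM, which is a limit of the assay and not a number.

Compound 2 therefore stands at the weak end of what this assay can report, as shown by the limit of > 1000 nM in this assay, at which 1 of the 2 values shown sits. Among the measured compounds shown here, the only measured step, an at least 1.0-fold higher number from compound 1 to compound 2 (0.03 log units; that floor lies within the scatter), is bounded by that limit and lies within the scatter, so it does not show a real change between the 5-(4-methylpiperazin-1-yl)pentyl chain and the triazolyl chain. Compound 3 `O=C1c2c[n+]([O-])c3ccccc3c2C(=O)c2c1c1ccccc1n2CCN1CCCCC1` differs from compound 2 by (piperidin-1-yl)methyl in place of 1-(2,3-dihydroxypropyl)-1H-1,2,3-triazol-4-yl on a saturated chain carbon bound to an aromatic nitrogen. For the measured compounds named here, no measured step covers this exchange, and the starting point is itself a limit, so the expectation is loose. Compound 3 is estimated at 1000 nM, within a range from 300 nM to 3500 nM. This estimate corresponds to an expected step of a number no higher from compound 2 to compound 3 (the limit leaves the size open).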

Compound 3, half-maximal inhibitory concentration: 1860 nM
Estimate against measurement, compound 3: 1.9-fold (0.27 log units) below, and the stated range covers the measured number.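

The piperidin-1-yl group in place of 4-(4-methylpiperazin-1-yl)butyl, on a saturated chain carbon, two bonds along the chain from an aromatic nitrogen, gives a 2.0-fold higher number from compound 1 to compound 3 (0.31 log units; beyond the scatter) in this assay. Among the compounds shown here, this is the first readable step that lies beyond the scatter, so the group carried on this chain can shift the cytotoxicity number, though only modestly and in the direction of weaker inhibition here. The exchange starting from compound 2 cannot be read, because that compound gives only a limit of the assay and not a number: the limit of > 1000 nM in this assay, at which 1 of the 3 values shown sits.

The step from compound 1 to compound 3 alters the length of the chain and the ring at its end together, so the compounds shown do not separate the two. A piperidine on a longer chain, or a morpholine on the short chain, would address that question.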